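A Bromophenyl Amide on the Shared Core

The source may hold more compounds than are shown below. What is called first, only, known or untested is meant among the compounds shown, and "the series" means these compounds.

Of the compounds shown here, three built on one shared core have been measured in a functional assay on DU-145 cells (Homo sapiens) for inhibition, read by MTT assay, with a stated time of 24 h; on this read-out higher numbers stand for weaker inhibition and lower numbers for stronger inhibition. Compound 1 `CCOC(=O)C1=Cc2ccccc2OC1(OCc1cn(CC(=O)Nc2cccc(Cl)c2)nn1)C(F)(F)F` gives 10100 nM. Compound 3 `CCOC(=O)C1=Cc2ccccc2OC1(OCc1cn(CC(=O)Nc2ccc(OC)cc2)nn1)C(F)(F)F` gives 32700 nM, the higher of the two plain numbers shown, with compound 1 nearest to it. Compound 2 `CCCCCCCCn1cc(COC2(C(F)(F)F)Oc3ccccc3C=C2C(=O)OCC)nn1` reaches only a limit of the assay, > 150000 nM. The step of a 3.2-fold higher number from compound 1 to compound 3 (0.51 log units; beyond the scatter) is modest, while the step of an at least 14-fold higher number from compound 1 to compound 2 (1.17 log units; beyond the scatter) is large and rests on (the limit of > 150000 nM in this assay, at which 1 of the 3 values shown sits); the step of an at least 4.5-fold lower number from compound 2 to compound 3 (0.66 log units; beyond the scatter) is at least modest.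

Compound 4 `CCOC(=O)C1=Cc2ccccc2OC1(OCc1cn(CC(=O)Nc2ccccc2Br)nn1)C(F)(F)F` differs from compound 3 in one place: 2-bromophenyl in place of 4-methoxyphenyl on an amide-type nitrogen. The step from compound 1 to compound 3 bears on this change most directly, since compound 1, whose amide-type nitrogen carries 3-chlorophenyl, gives 10100 nM. A modest move toward a lower number is therefore expected in this assay. The estimate for compound 4 is 15000 nM, with a range from 5000 nM to 50000 nM. That expectation amounts to the step of a 2.2-fold lower number from compound 3 to compound 4 (0.34 log units; beyond the scatter).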

Compound 4, half-maximal inhibitory concentration: > 150000 nM
Compound 4 was reported as a limit; the forecaster's own chance of this, stated with the estimate: 10%; at least 10-fold (1.00 log units) between middle value and limit.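

In this assay, changing only the aryl group on the amide-type nitrogen can produce more than a modest shift: the result is an at least 4.5-fold higher number from compound 3 to compound 4 (0.66 log units; beyond the scatter), and an at least 14-fold higher number from compound 1 to compound 4 (1.17 log units; beyond the scatter). Keeping an aryl amide on the shared core is therefore not enough to keep the number near those of compound 1 and compound 3. Compound 4 gives only a limit, so both steps are minimum sizes, and its step from compound 2 cannot be read, as the two compounds sit at the same limit: the limit of > 150000 nM in this assay, at which 2 of the 4 values shown sit.

Compound 1 and compound 4 differ in both the halogen and where it sits on the ring, so the effects of these two features remain unseparated. A 2-chlorophenyl or 3-bromophenyl group would separate them, while an unsubstituted phenyl group would show how the ring behaves without any added group.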